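Pyridinyl in place of methoxyphenyl on the amide carbonyl

This account rests on a few compounds, and the source may have more. Where it says the series, first, only, none or still open, it means among the compounds named here.

For the measured compounds named here, compound 1 `COc1cccc(C(=O)Nc2cc(-c3ccccc3)nn2-c2ccccc2)c1` gives 102 nM in a functional assay on cells for positive allosteric modulation of metabotropic glutamate receptor 5 (Rattus norvegicus), read by calcium flux (on this read-out higher numbers stand for an effect only at larger amounts of compound and lower numbers for an effect already at smaller amounts), the lowest of the three numbers so far. Compound 2 `O=C(Nc1cc(-c2ccccc2)nn1-c1ccccc1F)c1ccccc1` gives 104 nM, which lies within the scatter of that, while compound 3 `O=C(Nc1cc(-c2ccccc2)nn1-c1cccc(Br)c1)c1ccccc1` gives 400 nM, which lies beyond it. Going by the values given here, the one measured step, a 3.8-fold higher number from compound 2 to compound 3 (0.59 log units; beyond the scatter), alters the group on an aromatic nitrogen. Compound 4 `O=C(Nc1cc(-c2ccccc2)nn1-c1ccccc1)c1ccncc1` differs from compound 1 at a different place: pyridin-4-yl in place of 3-methoxyphenyl on a carbonyl carbon. Among the compounds with values here, no measured step touches the carbonyl carbon, so nothing in this set scales that change. The step of a 1.5-fold higher number from compound 1 to compound 4 (0.17 log units; within the scatter) is therefore expected to stay close to the scatter, with no clear direction. Compound 4 is thus estimated at 150 nM, within 50 nM to 500 nM.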

Compound 4, half-maximal effective concentration: 2500 nM
Beside the measured number, compound 4's estimate is 17-fold (1.22 log units) below it; the whole stated range lies below it.
By their numbers in this assay, from the lowest: compounds 1 and 2 (each within the scatter of the next); then compound 3; then compound 4.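

The carbonyl carbon proves sensitive in this assay: a 25-fold higher number from compound 1 to compound 4 (1.39 log units; beyond the scatter), a large step where the earlier compounds had shown a measured step only on the aromatic nitrogen. Pyridin-4-yl and 3-methoxyphenyl have the same counts of hydrogen-bond donors and acceptors and the same net charge, so these counts do not separate the two groups. No evidence is available on what lies behind this step. The compounds shown leave open whether the ring nitrogen or the lost methoxy group accounts for the step, and how pyridin-3-yl or a methoxypyridinyl group would read at this position.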